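The source may report more compounds than this note shows. Statements on the series, on what has been measured and on what is new or still open speak of the compounds shown alone.

Going by the values given here, compound 2, `COc1ccc(C(=O)/C=C/c2cc(-c3cc(OC)c(OC)c(OC)c3)n[nH]2)cc1OC`, gives 2480 nM in a functional assay on U-251 cells (Homo sapiens) for inhibition, read by sulforhodamine B assay, with a stated time of 48 h (on this read-out lower numbers stand for stronger inhibition of growth and higher numbers for weaker inhibition of growth), the lowest of the two numbers so far. Among the compounds with values here, compound 1, `COc1cc(-c2cc(/C=C/C(=O)c3ccc(Cl)c(Cl)c3)[nH]n2)cc(OC)c1OC`, gives 80500 nM in this assay, and the step of a 32-fold lower number from compound 1 to compound 2 (1.51 log units; beyond the scatter) is the only measured step in this set; it concerns the aryl group on the carbonyl carbon, the same part of the molecule that changes next. Compound 3, `COc1cc(C(=O)/C=C/c2cc(-c3cc(OC)c(OC)c(OC)c3)n[nH]2)cc(OC)c1OC`, differs from compound 2 by methoxy in place of hydrogen on an aromatic carbon. Within the data shown here, no measured step shows what a further methoxy at this place does, so the one measured step offers no direct guide to its size or direction. A change that stays within the usual scatter is therefore expected, with a modest shift in either direction possible. Compound 3 is estimated at 2000 nM in this assay, in the range 600 nM to 7000 nM, which would mean the expected step of a 1.2-fold lower number from compound 2 to compound 3 (0.09 log units; within the scatter).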

Compound 3, concentration for total growth inhibition: 2960 nM
Beside the measured number, compound 3's estimate is 1.5-fold (0.17 log units) below it, and the stated range covers the measured number.
By their numbers in this assay, from the lowest: compounds 2 and 3 (each within the scatter of the next); then compound 1.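

The step of a 1.2-fold higher number from compound 2 to compound 3 (0.08 log units; within the scatter) in this assay shows that this aromatic carbon, ortho to a methoxy group and meta to a large group, can carry methoxy in place of hydrogen with no shift that stands out from the scatter. The aryl group on the carbonyl carbon therefore matters in one case and not in the other: the exchange of chlorines for methoxy groups in a 32-fold lower number from compound 1 to compound 2 (1.51 log units; beyond the scatter) lies beyond the scatter, while this added methoxy does not. Nothing available bears on the reason for this result.

From the compounds shown here alone, it remains open whether another group at this place, such as an amine, a hydroxyl or a longer alkoxy chain, would behave the same way. Also open, going by these compounds, is whether methoxy here would have as little effect on the 3,4-dichlorophenyl group of compound 1.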